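This account rests on a few compounds, and the source may have more. Where it says the series, first, only, none or still open, it means among the compounds named here.

Measured compounds:

Compound 1 `CN(C)CCn1cnnc1-c1cc(Oc2ccc(NC(=O)N/N=C/c3ccc(Cl)cc3Cl)cc2F)ccn1` gives 750 nM in a functional assay on MKN-45 cells (Homo sapiens) for cytotoxicity, read by MTT assay, with a stated time of 72 h; a lower number here means a stronger inhibitor, a higher number a weaker inhibitor.
Compound 2 `CN(C)CCn1cnnc1-c1cc(Oc2ccc(NC(=O)N/N=C/c3c(Cl)cccc3Cl)cc2F)ccn1` gives 160 nM in this assay.
Compound 3 `COc1ccc(OC)c(/C=N/NC(=O)Nc2ccc(Oc3ccnc(-c4nncn4CCN(C)C)c3)c(F)c2)c1` gives 1510 nM in this assay.

Among these three numbers compound 1 stands second highest; its nearest neighbour is compound 3, separated by a gap within the scatter, and its furthest is compound 2, which shows a 4.7-fold lower number from compound 1 to compound 2 (0.67 log units; beyond the scatter). Compound 4 `COc1ccc(/C=N/NC(=O)Nc2ccc(Oc3ccnc(-c4nncn4CCN(C)C)c3)c(F)c2)cc1O` has not been measured. It differs from compound 1 in one place: 3-hydroxy-4-methoxyphenyl in place of 2,4-dichlorophenyl on a carbon with a double bond to nitrogen.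

Going by the values given here, two measured steps bear on this change. The move to 2,6-dichlorophenyl gave a 4.7-fold lower number from compound 1 to compound 2 (0.67 log units; beyond the scatter), while the move to 2,5-dimethoxyphenyl gave a 2.0-fold higher number from compound 1 to compound 3 (0.30 log units; within the scatter), a gap inside the scatter. The entering 3-hydroxy-4-methoxyphenyl resembles the oxygen-bearing ring of compound 3 more than the chlorinated ring of compound 2, so no shift beyond the scatter is expected, with a slight drift toward a higher number as the likelier direction.

Compound 4 is therefore estimated at 1300 nM, with a range from 500 nM to 3500 nM, which means an expected step of a 1.7-fold higher number from compound 1 to compound 4 (0.24 log units; within the scatter).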

Compound 4, half-maximal inhibitory concentration: 2510 nM
Compound 4: the middle estimate sits 1.9-fold (0.29 log units) below what was measured; low and high end bracket the measured number.
By their numbers in this assay, from the lowest: compound 2; then compounds 1, 3 and 4 (each within the scatter of the next, the first and the last beyond it).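

In this assay, 3-hydroxy-4-methoxyphenyl on the carbon with a double bond to nitrogen gives a 3.3-fold higher number from compound 1 to compound 4 (0.52 log units; beyond the scatter), so replacing 2,4-dichlorophenyl with an oxygen-bearing ring can move the number beyond the scatter, which the step to compound 3 did not show. The comparison between the two oxygen-bearing rings gives a 1.7-fold higher number from compound 3 to compound 4 (0.22 log units; within the scatter), so these two different arrangements of hydroxy and methoxy groups cannot be told apart here. Against 2,6-dichlorophenyl, the new ring gives a 16-fold higher number from compound 2 to compound 4 (1.20 log units; beyond the scatter), the widest gap shown at this position, which widens the range this single change can span with the rest of the structure held constant.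

The compounds shown leave open whether a 2,6-difluorophenyl ring, or a ring carrying an amine or a carboxylic acid, would fall near compound 2 or near compound 4. Nothing shown accounts for these differences.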